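This account rests on a few compounds, and the source may have more. Where it says the series, first, only, none or still open, it means among the compounds named here.

In an ADME assay on the whole organism (Mus musculus, strain C57) for pharmacokinetics, at a dose of 20 mg/kg by the oral route (on this read-out higher numbers stand for higher oral bioavailability and lower numbers for lower oral bioavailability), compound 1 `Cc1cc(C(F)(F)F)ccc1-c1cc2cnn([C@@H](CC(C)C)c3ccc(C(=O)NCCC(=O)O)cc3)c2cc1C` gives 70.1%. For the measured compounds named here, the only other measured compound, compound 2 `Cc1cc(C(F)(F)F)ccc1-c1cc2cn([C@@H](CC(C)C)c3ccc(C(=O)NCCC(=O)O)cc3)nc2cc1C`, gives 74.4%, and these two values lie within the usual scatter of each other. Compound 1 therefore stands level with compound 2. Compound 3 `Cc1cc2c(cnn2[C@@H](CC(C)C)c2ccc(C(=O)NCCC(=O)O)cc2)cc1-c1ccc(C(F)(F)F)cc1Cl` has not yet been measured. It differs from compound 1 in one place: chloro in place of methyl on an aromatic carbon. This is chloro in place of methyl on an aromatic carbon, ortho to a large group and meta to a trifluoromethyl group, turning 2-methyl-4-(trifluoromethyl)phenyl into 2-chloro-4-(trifluoromethyl)phenyl. Going by the values given here, no measured pair of compounds shows this exchange, so the data do not size it directly. No change beyond the scatter is expected in this assay, in either direction. The estimated step is a number 2.1 percentage points lower from compound 1 to compound 3 (within the scatter). Compound 3 is expected at 68%, with an estimated range from 50% to 84%.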

Compound 3, oral bioavailability: 121%
Compound 3: middle estimate off by 53 percentage points, on the low side; the whole stated range lies below it.
By their numbers in this assay, from the lowest: compounds 1 and 2 (each within the scatter of the next); then compound 3.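

Turning 2-methyl-4-(trifluoromethyl)phenyl into 2-chloro-4-(trifluoromethyl)phenyl gives a number 50.9 percentage points higher from compound 1 to compound 3 (beyond the scatter) in this assay, so this one exchange moves the read-out well beyond the scatter. Compound 1 and compound 2 gave no view of this place, and the pair now shows that the position, ortho to a large group and meta to a trifluoromethyl group, can matter greatly in this assay, even though the exchange swaps one heavy atom for one and adds no ring, hydrogen-bond donor, hydrogen-bond acceptor or net charge. No measurement shown here bears on why the step arises. From the compounds shown here alone, whether fluoro, methoxy or a nitrile at this place would give a similar step remains open. So does whether chloro in place of methyl would give the same step on the core of compound 2.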